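Acetamido for methoxy on the biphenyl-type core

The source may hold more compounds than are shown below. What is called first, only, known or untested is meant among the compounds shown, and "the series" means these compounds.

For the measured compounds named here, compound 1 `COc1ccc(-c2ccc(C(O)(c3c[nH]cn3)C(C)C)cc2)cc1` gives 120 nM in an assay on microsomes from Testis (strain Sprague-Dawley) for inhibition of steroid 17-alpha-hydroxylase/17,20 lyase (Rattus norvegicus) (a lower number here means a stronger inhibitor, a higher number a weaker inhibitor), the highest number among the three measured members. Compound 2 `CC(C)C(O)(c1cccc(-c2ccc(F)cc2)c1)c1c[nH]cn1` gives 8.3 nM and compound 3 `CC(=O)Nc1cccc(-c2ccc(C(O)(c3c[nH]cn3)C(C)C)cc2)c1` gives 17 nM; both gaps to compound 1 lie beyond the scatter. Compound 4 `CC(=O)Nc1ccc(-c2ccc(C(O)(c3c[nH]cn3)C(C)C)cc2)cc1` is not yet measured. Relative to compound 1 the change is acetamido in place of methoxy on an aromatic carbon, on an aromatic carbon of a six-membered aromatic ring of carbon only, para to a large group. Going by the values given here, no measured pair shares exactly this change. A step toward a lower number, of moderate size, is expected for compound 4 because compound 3 with its acetamido gives 17 nM. The expected step of a 2.7-fold lower number from compound 1 to compound 4 (0.43 log units; beyond the scatter) is uncertain, since the acetamido of compound 3 sits at a different place. Compound 4 is estimated at 45 nM, within 15 nM to 150 nM.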

Compound 4, half-maximal inhibitory concentration: 24 nM
Estimate against measurement, compound 4: 1.9-fold (0.27 log units) above, and the stated range covers the measured number.
By their numbers in this assay, from the lowest: compound 2; then compounds 3 and 4 (each within the scatter of the next); then compound 1.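

In this assay, for the compounds shown here, acetamido in place of methoxy on an aromatic carbon, para to a large group, gives a 5.0-fold lower number from compound 1 to compound 4 (0.70 log units; beyond the scatter), the first direct reading of this change at this position. Compound 3 at 17 nM and compound 4 at 24 nM lie within the scatter of each other, so the two acetamido placements cannot be told apart here. No measurement on hand accounts for the step.

Open, on these data alone, is how an amine or a carboxylic acid at this position would compare with acetamido. Also open, as far as these compounds go, is whether a longer chain on the carbonyl would keep the value of compound 4.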